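Cyclopentyl in place of tert-butyl on compound 2

The compounds below may be only part of what the source reports. "The series", "measured", "known", "first", "only" and "open" are said of these compounds alone.

Three compounds have been measured in an assay on isolated protein for displacement of a labelled ligand from melanin-concentrating hormone receptor 1 (Homo sapiens); on this read-out higher numbers stand for weaker inhibition and lower numbers for stronger inhibition:
compound 1, `CCCc1cc(N)c2cc(NC(=O)/C=C/c3ccc(Cl)cc3)ccc2n1`, gives 6 nM;
compound 2, `CC(C)(C)c1cc(N)c2cc(NC(=O)/C=C/c3ccc(C(F)(F)F)cc3)ccc2n1`, gives 0.3 nM;
compound 3, `CCCc1cc(N)c2cc(NC(=O)/C=C/c3ccc(Br)cc3)ccc2n1`, gives 4 nM.

Compound 2 stands lowest of the three in this assay. Its nearest neighbour is compound 3, whose number is higher by an amount beyond the scatter, and compound 1 lies further still. For the measured compounds named here, compound 2 differs from both of them in two places, so no single step connects it to either; the values alone show that it sits clearly below them.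

Going by the values given here, the only step among the measured compounds is a 1.5-fold lower number from compound 1 to compound 3 (0.18 log units; within the scatter). It concerns a different place on the shared core and says nothing about the group that sits on the ring carbon studied here.

Compound 4, `Nc1cc(C2CCCC2)nc2ccc(NC(=O)/C=C/c3ccc(C(F)(F)F)cc3)cc12`, is not yet measured. It differs from compound 2 as follows: cyclopentyl in place of tert-butyl on an aromatic carbon. Among the compounds with values here, no measured step bears on this change. Both groups are saturated carbon, similar in size, and nothing in the data points to a shift in either direction. Compound 4 is therefore expected to stay close to compound 2, with the estimated step of a 1.7-fold higher number from compound 2 to compound 4 (0.22 log units; within the scatter) lying within or only just beyond the scatter. In this assay compound 4 is estimated at 0.5 nM, in the range 0.15 nM to 2 nM.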

Compound 4, half-maximal inhibitory concentration: 0.8 nM
The estimate for compound 4 lay 1.6-fold (0.20 log units) below the measured number; the measured number falls inside the stated range.
By their numbers in this assay, from the lowest: compound 2; then compound 4; then compounds 3 and 1 (each within the scatter of the next).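

In this assay, for the compounds shown here, the only measured step at this position, on the aromatic carbon next to the ring nitrogen, is a 2.7-fold higher number from compound 2 to compound 4 (0.43 log units; beyond the scatter), so cyclopentyl in place of tert-butyl costs a modest but real amount. The position still accepts a five-membered ring of carbon only, with compound 4 at 0.8 nM, yet the exchange is not neutral, even though neither group carries a hydrogen-bond donor, a hydrogen-bond acceptor or a net charge. Nothing available accounts for the difference between these two groups.

The compounds shown leave open how this position responds to groups of another kind, such as an amine, a methoxy group or a phenyl ring, and whether a smaller ring such as cyclopropyl or a larger one such as cyclohexyl would fall closer to tert-butyl. They also leave open whether the step from tert-butyl to cyclopentyl keeps its size when the trifluoromethyl group at the far end of the molecule is replaced by chloro or bromo.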